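The source may hold more compounds than are shown below. What is called first, only, known or untested is meant among the compounds shown, and "the series" means these compounds.

Compound 1 `NC(=O)C[C@H](NC(=O)c1cc2ccccc2cn1)C(=O)OCc1ccccc1` is one of three compounds that share a core and differ only in the group carried on the saturated chain carbon bound to an amide-type nitrogen and a carbonyl carbon. In a functional assay on the whole organism (CCRF S-180 cells, Mus musculus) for inhibition, in a xenograft, with stated times of 7 days and 24 h, at a dose of 100 umol/kg by the intraperitoneal route (a lower number here means less inhibition, a higher number more inhibition at the dose given (going by the name of the read-out)), compound 1 gives 36.7%, the second highest of the three numbers. Compound 2 `CSCC[C@H](NC(=O)c1cc2ccccc2cn1)C(=O)OCc1ccccc1` gives 39.6% in this assay. The step of a number 2.9 percentage points higher from compound 1 to compound 2 (within the scatter) lies within the scatter, so these two compounds are not told apart. Compound 3 `O=C(CNC(=O)c1cc2ccccc2cn1)OCc1ccccc1` gives 16.1% in this assay. The step of a number 20.6 percentage points lower from compound 1 to compound 3 (beyond the scatter) is beyond the scatter, and so is the step of a number 23.5 percentage points lower from compound 2 to compound 3 (beyond the scatter). Compound 4 `C[C@H](NC(=O)c1cc2ccccc2cn1)C(=O)OCc1ccccc1` has not yet been measured in this assay. It differs from compound 1 in one place: hydrogen in place of carbamoyl on a saturated chain carbon, two bonds along the chain from an amide-type nitrogen and a carbonyl carbon. The measured steps that bear on this change are a number 20.6 percentage points lower from compound 1 to compound 3 (beyond the scatter) and a number 23.5 percentage points lower from compound 2 to compound 3 (beyond the scatter); in both, the whole side group on that carbon gave way to hydrogen and the inhibition fell by a modest amount. In compound 4 a methyl remains on that carbon, so the change is smaller than in either of those steps, and a drop of intermediate size is expected for compound 4, namely a number 12.7 percentage points lower from compound 1 to compound 4 (beyond the scatter). Compound 4 is therefore estimated to give 24% in this assay, within a range from 10% to 38%.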

Compound 4, a percentage reported as inhibition, in the whole organism at one dose (the size of the read-out at that dose, not a potency): 40.6%
Estimate against measurement, compound 4: 16.6 percentage points below; measured number outside the range, above it.
By their numbers in this assay, from the lowest: compound 3; then compounds 1, 2 and 4 (each within the scatter of the next).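

In this assay the carbamoyl of compound 1 can give way to hydrogen with no change that the numbers can tell, the step being a number 3.9 percentage points higher from compound 1 to compound 4 (within the scatter) and the comparison with the other longer side group reading a number 1 percentage points higher from compound 2 to compound 4 (within the scatter) in the same way. For the compounds shown here, the carbamoyl and the methylsulfanyl of compounds 1 and 2 are thus not what sets these compounds apart from compound 3, for the one step that still stands beyond the scatter here is the smallest possible change on the saturated chain carbon bound to an amide-type nitrogen and a carbonyl carbon, methyl in place of hydrogen, at a number 24.5 percentage points higher from compound 3 to compound 4 (beyond the scatter) and no further group on the methyl adds anything that can be read. Nothing given here says why a single methyl on that carbon should carry this step.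

The compounds shown leave open whether an amine, a carboxylic acid or a chain longer than 2-(methylsulfanyl)ethyl on that carbon would keep the inhibition of compounds 1, 2 and 4 or lose it. They also leave open whether an ethyl or an isopropyl on that carbon would read any differently from the methyl of compound 4.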